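The source may hold more compounds than are shown below. What is called first, only, known or untested is meant among the compounds shown, and "the series" means these compounds.

Measured compounds:
- compound 1 `Cc1cc(C(=O)O)nn1Cc1cc(Br)ccc1OCc1ccccc1` gives 6.46 nM in an assay on CHO-K1 cells for displacement of a labelled ligand from prostaglandin E2 receptor EP1 subtype (Homo sapiens); on this read-out higher numbers stand for weaker inhibition and lower numbers for stronger inhibition
- compound 2 `O=C(O)c1ccn(Cc2cc(Br)ccc2OCc2ccccc2)n1` gives 9.77 nM
- compound 3 `O=C(O)c1nn(Cc2cc(Br)ccc2OCc2ccccc2)cc1Br` gives 457 nM

Among the three measured compounds, compound 1 has the lowest number in this assay. The step of a 1.5-fold higher number from compound 1 to compound 2 (0.18 log units; within the scatter) stays within the scatter, so compound 1 and compound 2 cannot be told apart on this read-out, whereas compound 3 lies far away, as the step of a 47-fold higher number from compound 2 to compound 3 (1.67 log units; beyond the scatter) shows.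

Compound 4 `Cc1cc(C(=O)O)nn1Cc1cc(Br)ccc1OCc1ccc(F)cc1F` differs from compound 1 in one place: 2,4-difluorophenyl in place of phenyl on a saturated chain carbon bound to an oxygen on an aromatic ring, which, cut one bond further out, reads benzyl to 2,4-difluorobenzyl. Neither of the measured steps bears on this change. Among the measured compounds shown here, the step from compound 1 to compound 2 and the step from compound 2 to compound 3 both sit on the shared core, at places the change to compound 4 leaves untouched, and no measured pair varies the benzyl group at all.

With nothing measured that speaks to this change, the expectation for compound 4 is a step of a 1.0-fold higher number from compound 1 to compound 4 (0.00 log units; within the scatter) that remains within the scatter. Compound 4 is therefore estimated at 6.5 nM in this assay, with a range from 2 nM to 25 nM.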

Compound 4, half-maximal inhibitory concentration: 0.525 nM
For compound 4 the middle estimate is 12-fold (1.09 log units) above the measured one, and the stated range ends above it.
By their numbers in this assay, from the lowest: compound 4; then compounds 1 and 2 (each within the scatter of the next); then compound 3.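

The benzyl group on the oxygen turns out to be a place where the read-out responds: in this assay, 2,4-difluorobenzyl in place of benzyl gives a 12-fold lower number from compound 1 to compound 4 (1.09 log units; beyond the scatter) on an otherwise unchanged molecule. The earlier changes all lay on the shared core, and the only large step among them, a 47-fold higher number from compound 2 to compound 3 (1.67 log units; beyond the scatter), went towards a higher number, so this is the first change shown that lowers the number beyond the scatter. Nothing in the data at hand accounts for this step.

Still open, going by these compounds, is whether a single fluorine would do the same, or whether chloro or methoxy on the phenyl, or phenethyl in place of benzyl, would move the number in the same direction. Also open, on these data alone, is whether the gain from 2,4-difluorobenzyl carries over to the core of compound 2 or compound 3, or survives an amide in place of the carboxylic acid.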